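This account rests on a few compounds, and the source may have more. Where it says the series, first, only, none or still open, it means among the compounds named here.

Measured in a functional assay on SK-MEL-2 cells (Homo sapiens) for cytotoxicity; a lower number here means a stronger inhibitor, a higher number a weaker inhibitor:
- Compound 1 `O=C1NC(c2ccc(Br)cc2)CN1S(=O)(=O)c1ccc2c(c1)CCC2`: 32600 nM
- Compound 2 `O=C1NC(c2ccccc2)CN1S(=O)(=O)c1ccc2c(c1)CCC2`: 2 nM

Of the two measured compounds, compound 2 holds the lower number, at 2 nM. Compound 3 `Cc1ccc(C2CN(S(=O)(=O)c3ccc4c(c3)CCC4)C(=O)N2)cc1`, not yet measured, departs from it by methyl in place of hydrogen on an aromatic carbon, or phenyl to 4-methylphenyl.

Among the measured compounds shown here, only one measured step bears on this change: a 16000-fold lower number from compound 1 to compound 2 (4.21 log units; beyond the scatter), with hydrogen in place of bromo on an aromatic carbon. Compound 1 carries its bromo on the same carbon that takes the methyl in compound 3. For the measured compounds named here, that single large step suggests that a group there may cost much in this assay, but methyl is a different group and no measured compound carries it, so the size stays uncertain. An upward move beyond the scatter is expected, smaller than the bromo step. The expected step is a 150-fold higher number from compound 2 to compound 3 (2.18 log units; beyond the scatter). For compound 3 the estimated value is 300 nM, with an expected range of 5 nM to 20000 nM.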

Compound 3, half-maximal inhibitory concentration: 72500 nM
Compound 3: middle estimate off by 240-fold (2.38 log units), on the low side; measured number above the stated range.
By their numbers in this assay, from the lowest: compound 2; then compound 1; then compound 3.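

In this assay methyl on this aromatic carbon, para to a large group, brings a 36000-fold higher number from compound 2 to compound 3 (4.56 log units; beyond the scatter) and thus shows that the earlier loss did not belong to bromo alone. The two substituted compounds lie close together, with a 2.2-fold higher number from compound 1 to compound 3 (0.35 log units; beyond the scatter) as a modest change, small beside the step that either group makes from hydrogen. Among the three compounds, only compound 2, the one with hydrogen at this carbon, holds a low number, and both groups placed there give a high one.

Whether any group on this carbon can keep the number low stays open, as fluorine, a hydroxyl group and an amine appear in none of the compounds shown. Nothing available accounts for the size of the loss.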